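This account rests on a few compounds, and the source may have more. Where it says the series, first, only, none or still open, it means among the compounds named here.

Measured in a functional assay on HCT-116 cells (Homo sapiens) for inhibition, read by CCK-8 assay, with a stated time of 48 h; on this read-out higher numbers stand for weaker inhibition and lower numbers for stronger inhibition:
- Compound 1 `CCN1CCN(CC(=O)N(Cc2ccc(OC)cc2)c2cc(OC)c(OC)c(OC)c2)CC1`: > 20000 nM
- Compound 2 `COc1cc(N(Cc2ccc(Cl)cc2)C(=O)CSC(=S)N2CCN(C(=O)OC(C)(C)C)CC2)cc(OC)c1OC`: 8490 nM

Compound 1 reached only a limit of the assay, so its entry of > 20000 nM is not a true number. Among the compounds with values here, compound 2, at 8490 nM, therefore holds the only actual number so far, and it is a micromolar-range starting point rather than a strong result.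

Compound 3 `COc1ccc(CN(C(=O)CSC(=S)N2CCN(C(=O)OC(C)(C)C)CC2)c2cc(OC)c(OC)c(OC)c2)cc1C` keeps the rest of compound 2 but has 4-methoxy-3-methylphenyl in place of 4-chlorophenyl on a saturated chain carbon bound to an amide-type nitrogen.

Within the data shown here, no measured pair shows what such a swap does in this assay, so any forecast is loose. A moderate move toward stronger inhibition seems likely, though a result close to compound 2 would be no surprise. The expected step is a 2.4-fold lower number from compound 2 to compound 3 (0.38 log units; beyond the scatter). Compound 3 is estimated at 3500 nM, within an expected range of 600 nM to 15000 nM.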

Compound 3, half-maximal inhibitory concentration: > 20000 nM
Compound 3: only a limit was reported; the forecaster's own chance of this, stated with the estimate: 10%; at least 5.7-fold (0.75 log units) between middle value and limit.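

In this assay, 4-methoxy-3-methylphenyl in place of 4-chlorophenyl on a saturated chain carbon bound to an amide-type nitrogen gives an at least 2.3-fold higher number from compound 2 to compound 3 (0.37 log units; beyond the scatter). Within the data shown here, this is the first step that can be read in the set, and it shows that this position is not indifferent to what it carries: with this swap, the inhibition that gave compound 2 its measured number falls out of the range the assay reports. The true size of the step remains unknown, because compound 3 stops at a limit and not at a number: the limit of > 20000 nM in this assay, at which 2 of the 3 values shown sit.

The swap removes the chlorine and adds a methoxy and a methyl together, so the compounds shown cannot say which of these changes counts. A plain phenyl group, or a bromine in place of the chlorine, would leave that question open too.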